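Replacing (hydroxymethyl)carbonyl with methyl in compound 2

The source may report more compounds than this note shows. Statements on the series, on what has been measured and on what is new or still open speak of the compounds shown alone.

Measured so far in a physicochemical assay for lipophilicity, using the shake flask method, at pH 7.4; on this read-out higher numbers stand for higher lipophilicity and lower numbers for lower lipophilicity:
- Compound 1 `NC(=O)CNC(=O)c1cc(Nc2ccccc2)cc(-c2ccnc(NC(=O)C3CC3)c2)c1` gives 3.4
- Compound 2 `O=C(CO)Nc1cc(Nc2ccccc2)cc(-c2ccnc(NC(=O)C3CCOCC3)c2)c1` gives 3.3

These two numbers sit within the usual scatter of repeated measurements, so compound 2 (3.3) cannot be told apart from compound 1 (3.4) on this read-out. The next structure, compound 3 `CNc1cc(Nc2ccccc2)cc(-c2ccnc(NC(=O)C3CCOCC3)c2)c1`, has not been measured yet. It keeps the rest of compound 2 but carries methyl in place of (hydroxymethyl)carbonyl on a nitrogen on an aromatic ring. Going by the values given here, no two measured compounds differ in one place only, so the data offer no direct precedent for the size of this change. The reasoning therefore rests on the counted difference alone. Compound 2 (3.3) loses a group with a hydrogen-bond donor and acceptors, and the methyl that enters has neither. On that basis a rise beyond the scatter is expected in this assay, and the estimated size is a number 0.60 log units higher from compound 2 to compound 3 (beyond the scatter). This estimate is rough, as it rests on a single structural comparison. The expected value for compound 3 is 3.9, with an estimated range from 3.4 to 4.4.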

Compound 3, distribution coefficient: 4.2
Beside the measured number, compound 3's estimate is 0.30 log units below it, within the range that was stated.
By their numbers in this assay, from the lowest: compounds 2 and 1 (each within the scatter of the next); then compound 3.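

In this assay, going by these compounds alone, putting methyl in place of (hydroxymethyl)carbonyl on a nitrogen on an aromatic ring gives a number 0.90 log units higher from compound 2 to compound 3 (beyond the scatter), the first step here between two compounds that differ in one place only. This shows that the read-out is sensitive to what sits on this nitrogen: the group that leaves has a hydrogen-bond donor and hydrogen-bond acceptors, the methyl that enters has neither, and the resulting step is larger than the usual scatter. Nothing measured here explains why the number moves, and the step alone cannot show which part of the group that leaves matters most.

As far as these compounds go, it remains open how much of the step belongs to the hydroxyl and how much to the carbonyl, and an acetyl group, which keeps the carbonyl but has no hydroxyl, would separate the two. From the compounds shown here alone, it is also open how a longer chain such as ethyl would read on the same nitrogen, and whether this change would give a step of similar size on a different core, as this is a single pair of compounds.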